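The source may hold more compounds than are shown below. What is called first, only, known or untested is meant among the compounds shown, and "the series" means these compounds.

Measured in an ADME assay on PBMC cells (Homo sapiens) for cytotoxicity; on this read-out higher numbers stand for lower toxicity in this test and lower numbers for higher toxicity in this test:
- Compound 1 `CC(CCNC(=O)c1c(Cl)cncc1Cl)N1CCC(C(Oc2cccc(C#N)n2)c2ccc(C(F)(F)F)cc2)CC1`: 15700 nM
- Compound 2 `CCO/N=C(/c1ccc(Br)cc1)C1CCN(C(C)CCNC(=O)c2c(Cl)cncc2Cl)CC1`: 33800 nM
- Compound 3 `CCO/N=C(/c1ccc(Br)cc1)C1CCN(C(C)CCNC(=O)c2c(C)cc[n+]([O-])c2C)CC1`: > 177000 nM (a limit)

Of the two exact numbers, the lower belongs to compound 1 at 15700 nM, while compound 2 gives 33800 nM. Compound 3 reaches only a limit, > 177000 nM, not an exact number.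

Compound 4 `COc1cccc(OC(c2ccc(C(F)(F)F)cc2)C2CCN(C(C)CCNC(=O)c3c(Cl)cncc3Cl)CC2)n1` keeps the core of compound 1 and alters one group: methoxy in place of cyano on an aromatic carbon. In words, methoxy takes the place of cyano on an aromatic carbon, next to the ring nitrogen.

Going by the values given here, the one measured step, an at least 5.2-fold higher number from compound 2 to compound 3 (0.71 log units; beyond the scatter), exchanges the group on a carbonyl carbon. Among the compounds with values here, compound 4 keeps the carbonyl group of compound 1, so that step bears on this change only indirectly, and no measured step swaps cyano for methoxy. No step beyond the scatter is therefore expected in this assay, leaving compound 1 at 15700 nM as the starting point. The estimated change is a 1.0-fold lower number from compound 1 to compound 4 (0.02 log units; within the scatter). For compound 4 the expected value is 15000 nM, with an estimated range of 6500 nM to 35000 nM.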

Compound 4, half-maximal cytotoxic concentration: 32700 nM
For compound 4 the middle estimate is 2.2-fold (0.34 log units) below the measured one, and the stated range covers the measured number.
By their numbers in this assay, from the lowest: compound 1; then compounds 4 and 2 (each within the scatter of the next). At a limit, above all of these: compound 3.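

Going by these compounds alone, the only step measured before this one changed a group on a carbonyl carbon, so this is the first reading at the aromatic carbon next to the ring nitrogen: in this assay methoxy in place of cyano gives a 2.1-fold higher number from compound 1 to compound 4 (0.32 log units; beyond the scatter) and this modest step lies beyond the scatter. The position is therefore not silent in this test, even though the two groups have the same count of heavy atoms and of hydrogen-bond acceptors and neither carries a net charge. Nothing measured here says why the number moves.

As far as these compounds go, it remains open whether the same exchange would give a similar step on another part of the series, such as the core of compound 2. From the compounds shown here alone, it is also open what an amine, a chlorine or a longer chain such as ethoxy would do at this position.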